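From 3-hydroxyphenyl to 4-hydroxyphenyl: expected cytotoxicity

The source may report more compounds than this note shows. Statements on the series, on what has been measured and on what is new or still open speak of the compounds shown alone.

Measured compounds:
Compound 1 `Oc1ccc(-c2cc(-c3cccs3)cc(-c3ccccc3O)n2)cc1` gives > 50000 nM, a limit of the assay.
Compound 2 `Oc1ccc(-c2cc(-c3ccco3)cc(-c3ccccc3O)n2)cc1` gives > 50000 nM, also a limit.
Compound 3 `Oc1cccc(-c2cc(-c3ccoc3)cc(-c3ccccc3O)n2)c1` gives 2790 nM.

Going by the values given here, in a functional assay on DU-145 cells (Homo sapiens) for cytotoxicity, read by CCK-8 assay (a lower number here means a stronger inhibitor, a higher number a weaker inhibitor), compound 3 supplies the only definite number of the three. Compound 1 reports only a limit. Compound 2 likewise reports only a limit. Among the compounds with values here, the single measured step, a step that the two limits leave unreadable from compound 1 to compound 2, swaps the five-membered ring and cannot be read in size, so it says nothing directly about the change followed here. Compound 4 `Oc1ccc(-c2cc(-c3ccoc3)cc(-c3ccccc3O)n2)cc1` differs from compound 3 by 4-hydroxyphenyl in place of 3-hydroxyphenyl on an aromatic carbon. Compounds 1 and 2 also carry 4-hydroxyphenyl on the shared core and both sit at the limit of > 50000 nM in this assay, at which 2 of the 3 values shown sit, whereas compound 3 with 3-hydroxyphenyl gives a number. Compound 4 is therefore expected to be weaker, with an estimated step of a 7.2-fold higher number from compound 3 to compound 4 (0.86 log units; beyond the scatter). The estimate for compound 4 is 20000 nM, expected between 5000 nM and 80000 nM.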

Compound 4, half-maximal inhibitory concentration: 28000 nM
The estimate for compound 4 lay 1.4-fold (0.15 log units) below the measured number; the measured number falls inside the stated range.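

In this assay, 4-hydroxyphenyl in place of 3-hydroxyphenyl gives a 10-fold higher number from compound 3 to compound 4 (1.00 log units; beyond the scatter), the first readable size for this change at this position. The hydroxyl's place on this ring therefore matters, even though the two groups hold the same atoms. The five-membered ring steps give only floors within the scatter, an at least 1.7-fold lower number from compound 2 to compound 4 (0.25 log units; that floor lies within the scatter) and an at least 1.7-fold lower number from compound 1 to compound 4 (0.25 log units; that floor lies within the scatter), so furan-3-yl shows no clear gain. Going by these compounds, whether 3-hydroxyphenyl gives a similar advantage alongside furan-2-yl or thiophen-2-yl remains open. So does the effect of an amine or a methoxy group in place of this hydroxyl.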